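The source may report more compounds than this note shows. Statements on the series, on what has been measured and on what is new or still open speak of the compounds shown alone.

Measured so far:
compound 1 `CC(C)(C)c1ccc(OCCCCN2CCN(c3ncccn3)CC2)cc1` — 20.8 nM
compound 2 `CCC(C)(C)c1ccc(OCCCCN2CCN(c3cccnc3)CC2)cc1` — 9.23 nM

Both compounds were tested in a functional assay on L5178Y cells (Mus musculus) for cytotoxicity, read by MTT assay; a lower number here means a stronger inhibitor, a higher number a weaker inhibitor. Compound 2 gives the lowest of the two numbers, with 9.23 nM, while compound 1 gives 20.8 nM, a gap that lies beyond the usual scatter. Compound 1 and compound 2 differ in two places at once, so their two values alone cannot tell which change carries the gap.

Compound 3 `CCC(C)(C)c1ccc(OCCCCN2CCN(c3ncccn3)CC2)cc1` has not yet been measured. It keeps the tail of compound 2 and changes only the group on the ring nitrogen: pyrimidin-2-yl in place of pyridin-3-yl on an amine nitrogen in a ring. Going by the values given here, compound 1 carries the same pyrimidin-2-yl group and shows the higher number, which gives a hint of direction but no clean step. A modest weakening is expected, with a 1.6-fold higher number from compound 2 to compound 3 (0.21 log units; within the scatter) as the step from compound 2 to compound 3. Compound 3 is estimated at 15 nM, within a range from 6 nM to 40 nM.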

Compound 3, half-maximal inhibitory concentration: 46.4 nM
Compound 3: middle estimate off by 3.1-fold (0.49 log units), on the low side; measured number above the stated range.
By their numbers in this assay, from the lowest: compound 2; then compound 1; then compound 3.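

The group on the ring nitrogen turns out to matter more than the opening pair suggested: in this assay, pyrimidin-2-yl in place of pyridin-3-yl gives a 5.0-fold higher number from compound 2 to compound 3 (0.70 log units; beyond the scatter). The tail matters too, since with pyrimidin-2-yl held fixed, methyl in place of hydrogen on a saturated chain carbon, two bonds along the chain from an aromatic carbon, gives a 2.2-fold higher number from compound 1 to compound 3 (0.35 log units; beyond the scatter). Both steps raise the number, so between compound 2 and compound 1 the two changes pull in opposite directions, and the gap between that pair hides the larger effect of the ring swap.

From the compounds shown here alone, whether other groups on that nitrogen, such as plain phenyl or pyridin-4-yl, would keep the lower number remains open, as does whether the methyl step would look the same with pyridin-3-yl in place. No measurement shown here explains why either change moves the number.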